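This account rests on a few compounds, and the source may have more. Where it says the series, first, only, none or still open, it means among the compounds named here.

Measured compounds:
compound 1, `C[C@H](Nc1cc(=O)oc2cc(OCc3ccccc3)ccc12)C(N)=O`, 680 nM in an assay for inhibition of Amine oxidase [flavin-containing] B (Rattus norvegicus); a lower number here means a stronger inhibitor, a higher number a weaker inhibitor;
compound 2, `C[C@H](Nc1cc(=O)oc2cc(OCc3cccc(Cl)c3)ccc12)C(N)=O`, 210 nM;
compound 3, `NC(=O)Cc1cc(=O)oc2cc(OCc3cccc(O)c3)ccc12`, 1000 nM.

Compound 1 stands second highest of the three numbers in this assay. Its nearest neighbour is compound 3, whose value lies within the usual scatter of compound 1, so no order between the two can be claimed. Among the measured compounds shown here, compound 2 gives the clearly lower number, and the only measured step, a 3.2-fold lower number from compound 1 to compound 2 (0.51 log units; beyond the scatter), concerns a change on the benzyl ring, not the position examined here.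

Compound 4, `CN(C)C(=O)Cc1cc(=O)oc2cc(OCc3ccccc3)ccc12`, differs from compound 1 in that place: (dimethylcarbamoyl)methyl in place of (1-carbamoylethyl)amino on an aromatic carbon. For the measured compounds named here, no measured step touches this group directly. Compound 3 carries a related carbamoylmethyl group there, but it also differs from compound 1 on the benzyl ring, so its value can only hint that such a swap need not move the number far. Compound 4 is therefore expected to stay near compound 1, with a step of a 1.3-fold higher number from compound 1 to compound 4 (0.12 log units; within the scatter) that may well fall within the scatter. The estimate for compound 4 is 900 nM, with a range from 300 nM to 3000 nM.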

Compound 4, half-maximal inhibitory concentration: 400 nM
The estimate for compound 4 lay 2.3-fold (0.35 log units) above the measured number; measured number inside the range.
By their numbers in this assay, from the lowest: compounds 2, 4, 1 and 3 (each within the scatter of the next, the first and the last beyond it).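

In this assay, replacing (1-carbamoylethyl)amino with (dimethylcarbamoyl)methyl on the aromatic carbon opposite the ring oxygen gives a 1.7-fold lower number from compound 1 to compound 4 (0.23 log units; within the scatter), so no real difference between the two groups can be claimed. Among the compounds shown here, this is the first direct reading at this position, and it shows that the swap can remove both hydrogen-bond donors and the defined stereocentre of the group that leaves without moving the number beyond the scatter. No supporting evidence is available to explain this result.

This single pair cannot show whether other groups at this position, such as a carboxylic acid or a simple amine, would behave the same way. As far as these compounds go, it also remains open whether a chloro group on the benzyl ring would have a similar effect when (dimethylcarbamoyl)methyl is present.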